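The source may report more compounds than this note shows. Statements on the series, on what has been measured and on what is new or still open speak of the compounds shown alone.

Measured in an ADME assay on HEp-2 cells (Homo sapiens) for cytotoxicity, read by MTT assay, with a stated time of 72 h; a lower number here means a stronger inhibitor, a higher number a weaker inhibitor:
- Compound 1 `COc1cc(C2=C(c3cc(C)c(OC)c(C)c3)C(OC(C)=O)CC2=O)cc(OC)c1OC`: > 100 ug/mL (a limit of the assay, not a number)
- Compound 2 `COc1ccc(C2=C(c3cc(OC)c(OC)c(OC)c3)C(=O)CC2OC(C)=O)cc1NC=O`: 3.27 ug/mL

Compound 1 gives no number, only a limit, and it stands at the limit of > 100 ug/mL in this assay, at which 1 of the 2 values shown sits. Compound 3 `COc1cc(C2=C(c3cc(C)c(OC)c(C)c3)C(O[SiH2]C(C)(C)C)CC2=O)cc(OC)c1OC` keeps the core of compound 1 and differs in one group: a group of 5 heavy atoms (4 carbon, 1 silicon; no ring) in place of a group of 3 heavy atoms (2 carbon, 1 oxygen; no ring), on an oxygen on a saturated carbon. The acetyl leaves, and a group of 5 heavy atoms takes its place on an oxygen on a saturated carbon.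

Among the measured compounds shown here, only one measured step is available, and it was large: an at least 30-fold lower number from compound 1 to compound 2 (1.48 log units; beyond the scatter). That step brought in 3-(formylamino)-4-methoxyphenyl on a double-bonded ring carbon, so it was made at a different place. For the measured compounds named here, no measured step touches the oxygen that changes in compound 3. The size of the step to compound 2 therefore cannot simply be carried over, and the data favour no direction. No step beyond the scatter is expected in this assay, although this expectation is weakly supported.

The expected step is an at least 1.2-fold lower number from compound 1 to compound 3 (0.09 log units; that floor lies within the scatter). For compound 3, the estimated value is 80 ug/mL, with an expected range from 15 ug/mL to 150 ug/mL.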

Compound 3, half-maximal inhibitory concentration: 26 ug/mL
The estimate for compound 3 lay 3.1-fold (0.49 log units) above the measured number, within the range that was stated.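

In this assay, the oxygen on a saturated carbon now has a measured step of its own: replacing the acetyl with the silicon-bearing group of 5 heavy atoms gives an at least 3.8-fold lower number from compound 1 to compound 3 (0.58 log units; beyond the scatter). Among the compounds shown here, this position therefore responds to change, since a swap here alone, with the rest of the core of compound 1 kept, moves the reading beyond the scatter, whereas the only earlier step was made on a double-bonded ring carbon. The step is only a floor and its true size remains unknown, because compound 1 gives a limit of the assay rather than a number: the limit of > 100 ug/mL in this assay, at which 1 of the 3 values shown sits.

Which part of the change matters stays open: it could be the silicon, the carbon atoms of the entering group, or simply the loss of the acetyl. A free hydroxyl or an all-carbon chain on this same oxygen would help separate these possibilities, and a single pair cannot show whether the swap would act in the same way on any other compound.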